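From isopropyl to chloromethyl on the shared core

The compounds below may be only part of what the source reports. "The series", "measured", "known", "first", "only" and "open" are said of these compounds alone.

In a toxicity assay on CCRF-CEM cells (Homo sapiens) for cytotoxicity (a higher number here means that more compound is tolerated, a lower number that less compound is tolerated), three compounds with a shared core differ in one group on an aromatic carbon. Compound 1 `Fc1cccc(F)c1Cn1c(-c2c(F)cccc2F)nc2c(Cl)cccc21`, which carries chloro there, gives 30.4 uM. Compound 3 `CC(C)c1cccc2c1nc(-c1c(F)cccc1F)n2Cc1c(F)cccc1F`, which carries isopropyl, gives 27 uM. The step between them is a 1.1-fold lower number from compound 1 to compound 3 (0.05 log units; within the scatter), so compound 3 stands level with compound 1. Compound 2 `CN(C)c1cccc2c1nc(-c1c(F)cccc1F)n2Cc1c(F)cccc1F`, which carries dimethylamino, reads > 100 uM, and this is a limit and not a number. Only dimethylamino separates from the other two groups, with an at least 3.2-fold higher number from compound 1 to compound 2 (0.51 log units; beyond the scatter) on entering and an at least 3.7-fold lower number from compound 2 to compound 3 (0.56 log units; beyond the scatter) on leaving.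

Compound 4 `Fc1cccc(F)c1Cn1c(-c2c(F)cccc2F)nc2c(CCl)cccc21` has chloromethyl in place of isopropyl on an aromatic carbon. Going by the values given here, no measured compound carries chloromethyl, so no step bears on this change directly. The nearest guide is the exchange of chloro for isopropyl at the same carbon, which gave a 1.1-fold lower number from compound 1 to compound 3 (0.05 log units; within the scatter). The two steps involving dimethylamino show that a change at this carbon can matter, so the range is kept wide. No step beyond the scatter is expected, and the estimated step is a 1.2-fold lower number from compound 3 to compound 4 (0.09 log units; within the scatter). For compound 4 the expected value is 22 uM, with an estimated range from 8 uM to 60 uM.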

Compound 4, half-maximal toxic concentration: 13.4 uM
Compound 4: the middle estimate sits 1.6-fold (0.22 log units) above what was measured; the measured number falls inside the stated range.
By their numbers in this assay, from the lowest: compounds 4, 3 and 1 (each within the scatter of the next, the first and the last beyond it). At a limit, above all of these: compound 2.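

Until now, in this assay, only dimethylamino had separated from the other groups at this aromatic carbon, but chloromethyl now gives a step beyond the scatter without it: a 2.3-fold lower number from compound 1 to compound 4 (0.36 log units; beyond the scatter) is a modest change of chloro for chloromethyl. Set against isopropyl, the same group shows a 2.0-fold lower number from compound 3 to compound 4 (0.30 log units; within the scatter) and stays within the scatter, so chloromethyl parts from chloro but not from isopropyl, even though chloro and isopropyl themselves stand level. The step with dimethylamino, an at least 7.4-fold lower number from compound 2 to compound 4 (0.87 log units; beyond the scatter), is the largest gap so far in size but has a limit of compound 2 at one end, and a limit is not a number: the limit of > 100 uM in this assay, at which 1 of the 4 values shown sits.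

The compounds shown leave open whether the separation from chloro belongs to the chlorine of the chloromethyl group, which a plain methyl, a hydroxymethyl or a bromomethyl group at this carbon could test. They also leave open whether dimethylamino stands alone at the limit or whether a smaller amine, such as methylamino, or a longer chain ending in an amine would read the same way.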